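This account rests on a few compounds, and the source may have more. Where it says the series, first, only, none or still open, it means among the compounds named here.

Compound 1 `COc1ccc(C(=O)/C=C/c2cccc(OCc3ccccc3)c2)cc1` has the lowest number of the three measured compounds in a functional assay on MCF7 cells (Homo sapiens) for cytotoxicity, read by MTT assay, with a stated time of 68 h (a lower number here means a stronger inhibitor, a higher number a weaker inhibitor), where compound 1 gives 6000 nM. Compound 2 `O=C(/C=C/c1cccc(OCc2ccccc2)c1)c1ccc(Cl)cc1Cl` gives 9400 nM and compound 3 `O=C(/C=C/c1cccc(OCc2ccccc2)c1)c1ccc(Cl)cc1` gives 24800 nM. Compound 4 `O=C(/C=C/c1cccc(OCc2ccccc2)c1)c1ccc(Cl)c(Cl)c1Cl` differs from compound 1 by 2,3,4-trichlorophenyl in place of 4-methoxyphenyl on a carbonyl carbon. For the measured compounds named here, two measured steps bear on this change. Swapping the same group for a ring carrying two chlorines gave a 1.6-fold higher number from compound 1 to compound 2 (0.19 log units; within the scatter), while exchanging the methoxy for a single chloro gave a 4.1-fold higher number from compound 1 to compound 3 (0.62 log units; beyond the scatter). Both point toward a higher number, so a modest weakening is expected, with the step of a 2.0-fold higher number from compound 1 to compound 4 (0.30 log units; within the scatter). Compound 4 is therefore estimated at 12000 nM, in a range from 5000 nM to 30000 nM.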

Compound 4, half-maximal inhibitory concentration: 2400 nM
Beside the measured number, compound 4's estimate is 5.0-fold (0.70 log units) above it; measured number outside the range, below it.
By their numbers in this assay, from the lowest: compound 4; then compounds 1 and 2 (each within the scatter of the next); then compound 3.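

Adding chlorines to the ring on the carbonyl carbon need not weaken the compound: in this assay, the 2,3,4-trichlorophenyl group brings a 10-fold lower number from compound 3 to compound 4 (1.01 log units; beyond the scatter) and a 3.9-fold lower number from compound 2 to compound 4 (0.59 log units; beyond the scatter), so across these three chlorinated compounds the number falls as chlorines are added. This ring also surpasses the 4-methoxyphenyl group, with a 2.5-fold lower number from compound 1 to compound 4 (0.40 log units; beyond the scatter), which neither ring with fewer chlorines did. No measurement here explains this result. Going by these compounds, whether the gain belongs to chlorine alone, or would also appear with a ring carrying bromine atoms or a nitrile, stays open.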